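The source may report more compounds than this note shows. Statements on the series, on what has been measured and on what is new or still open speak of the compounds shown alone.

Measured compounds, each with its number in a functional assay on SK-MEL-28 cells (Homo sapiens) for cytotoxicity, read by MTT assay; on this read-out higher numbers stand for weaker inhibition and lower numbers for stronger inhibition:

compound 1, `O=S(=O)(NCCNc1nccc(-c2c(-c3cccc(F)c3)nc3sccn23)n1)c1ccc(Br)cc1`: 13500 nM
compound 2, `O=C(NCCNc1nccc(-c2c(-c3cccc(F)c3)nc3sccn23)n1)c1c(F)cccc1F`: 11400 nM
compound 3, `O=S(=O)(NCCNc1nccc(-c2c(-c3cccc(F)c3)nc3sccn23)n1)c1ccc(F)cc1`: 9450 nM

Compound 3 holds the lowest of the three numbers, but its nearest neighbour, compound 2, sits only a 1.2-fold lower number from compound 2 to compound 3 (0.08 log units; within the scatter) away, and compound 1 sits a 1.4-fold lower number from compound 1 to compound 3 (0.15 log units; within the scatter) away, both within the scatter. The three compounds share one core and differ only in the group on the amine nitrogen of the side chain, and all three give numbers of the same order.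

Compound 4, `O=S(=O)(NCCNc1nccc(-c2c(-c3cccc(F)c3)nc3sccn23)n1)c1ccc(Cl)cc1`, is the next member. Its difference from compound 3 is chloro in place of fluoro on an aromatic carbon. Going by the values given here, the one measured step that bears on this directly is the exchange of bromo for fluoro at the same aromatic carbon, a 1.4-fold lower number from compound 1 to compound 3 (0.15 log units; within the scatter), which stayed within the scatter. The exchange of the whole sulfonyl group for a carbonyl group, a 1.2-fold lower number from compound 1 to compound 2 (0.07 log units; within the scatter), was likewise within the scatter. Chloro here replaces fluoro in the same place where bromo and fluoro gave indistinguishable numbers, so no step beyond the scatter is expected in this assay in either direction.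

Compound 4 is therefore estimated at 11000 nM, with a range of 5000 nM to 25000 nM, which means an expected step of a 1.2-fold higher number from compound 3 to compound 4 (0.07 log units; within the scatter).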

Compound 4, half-maximal inhibitory concentration: 18600 nM
Estimate against measurement, compound 4: 1.7-fold (0.23 log units) below; low and high end bracket the measured number.
By their numbers in this assay, from the lowest: compounds 3, 2, 1 and 4 (each within the scatter of the next).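

In this assay, chloro now joins fluoro and bromo on the aromatic carbon para to a large group, and neither step that brings it in leaves the scatter (a 2.0-fold higher number from compound 3 to compound 4 (0.29 log units; within the scatter) and a 1.4-fold higher number from compound 1 to compound 4 (0.14 log units; within the scatter)), although the first of these lies close to its limit. Replacing the (2,6-difluorophenyl)carbonyl group on the amine nitrogen with the (4-chlorophenyl)sulfonyl group also stays within the scatter (a 1.6-fold higher number from compound 2 to compound 4 (0.21 log units; within the scatter)), so none of the four compounds can be separated from the others, and neither the choice among these three halogens nor the choice between these two groups on the nitrogen shows a measurable effect here. Nothing measured alongside these numbers offers an account of them.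

On these data alone, it remains open whether any group on this aromatic carbon can move the number beyond the scatter, and a methoxy group, a nitrile, an amine or a carboxylic acid there would test this. As far as these compounds go, it is also open whether the number depends on the side chain itself, which a longer chain between the two nitrogens or a simple alkyl group on the amine nitrogen in place of the aromatic groups would address.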